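A few compounds are considered here, and "the series" means these few. Any claim that something is new, unique, unknown or untested is made for them only; others in the source may bear on it.

Compound 1 `Cc1ccc(S(=O)(=O)Nc2ccc3oc(-c4ccccc4)nc3c2)cc1` is the anchor of this comparison. Within the data shown here, in an ADME assay on HEK293 cells (Homo sapiens) for cytotoxicity, read by resazurin assay, with a stated time of 48 h (a lower number here means that less compound is tolerated, a higher number that more compound is tolerated), compound 1 gives 75000 nM, the only number among the two values shown. Compound 2 `O=S(=O)(Nc1ccc(-c2nc3ccccc3o2)cc1)c1ccccc1F` returns only a limit in this assay, > 100000 nM, and so stands at the limit of > 100000 nM in this assay, at which 1 of the 2 values shown sits, rather than at a number. Compound 3 `O=S(=O)(Nc1ccc2oc(-c3ccccc3)nc2c1)c1cccs1` differs from compound 1 in one place: thiophen-2-yl in place of 4-methylphenyl on a sulfonyl sulfur. Among the measured compounds shown here, no measured step of this kind is available, so the expectation rests on compound 1 alone; a shift from compound 1 to compound 3 of no more than the scatter is expected, in either direction. Compound 3 is therefore estimated at 80000 nM, with a range from 35000 nM to 150000 nM, the expected step being a 1.1-fold higher number from compound 1 to compound 3 (0.03 log units; within the scatter).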

Compound 3, half-maximal cytotoxic concentration: 97000 nM
Compound 3: middle estimate off by 1.2-fold (0.08 log units), on the low side; low and high end bracket the measured number.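

Among these compounds, at this position, the first measured step in this assay is a 1.3-fold higher number from compound 1 to compound 3 (0.11 log units; within the scatter), with thiophen-2-yl in place of 4-methylphenyl on a sulfonyl sulfur. This read-out therefore does not separate a five-membered aromatic ring with 1 hetero atom from a six-membered aromatic ring of carbon only at this place. No measured evidence shown bears on this step. From the compounds shown here alone, it remains open whether a longer chain or a group carrying an amine on a sulfonyl sulfur would also stay within the scatter of compound 1.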